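The source may report more compounds than this note shows. Statements on the series, on what has been measured and on what is new or still open speak of the compounds shown alone.

The measured compounds and their values:

Compound 1, `NNc1nc2ccc([N+](=O)[O-])cc2s1`, gives 12.8 ug/mL.
Compound 2, `Cc1ccc2nc(NN)sc2c1`, gives 4.52 ug/mL.
Compound 3, `Cc1cccc2sc(NN)nc12`, gives 9.8 ug/mL.

These three were run in an ADME assay on MT4 cells (Homo sapiens) for cytotoxicity, read by MTT assay, with a stated time of 5 days; a lower number here means that less compound is tolerated, a higher number that more compound is tolerated. Compound 1 and compound 2 differ in one place: nitro in place of methyl on an aromatic carbon. That change carried the number a 2.8-fold higher number from compound 2 to compound 1 (0.45 log units; beyond the scatter). Compound 3 shares the same atoms as compound 2, joined differently; the difference between the two cores is not broken down here. Compound 3 and compound 1 are within the scatter of each other, while compound 3 and compound 2 are beyond it.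

The unmeasured compound 4, `NNc1nc2c([N+](=O)[O-])cccc2s1`, is related to compound 3 by the same kind of change, (nitro in place of methyl on an aromatic carbon). The two places are not identical: in compound 4 the nitro sits ortho to a fused ring and meta to a fused ring, whereas in compound 1 it sits meta to a fused ring and para to a fused ring. Only one earlier example of this change exists among these compounds, so the expectation rests on a single step.

Compound 4 is expected to show a step of a 2.2-fold higher number from compound 3 to compound 4 (0.35 log units; beyond the scatter), estimated from the step of a 2.8-fold higher number from compound 2 to compound 1 (0.45 log units; beyond the scatter) and the value of compound 3, 9.8 ug/mL. Compound 4 is therefore estimated at 22 ug/mL, with a likely range from 9 ug/mL to 50 ug/mL.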

Compound 4, half-maximal cytotoxic concentration: 14.5 ug/mL
The estimate for compound 4 lay 1.5-fold (0.18 log units) above the measured number, and the stated range covers the measured number.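

In this assay, the change of nitro in place of methyl on an aromatic carbon now appears on a second core, where it gives a 1.5-fold higher number from compound 3 to compound 4 (0.17 log units; within the scatter). Set beside the earlier example, the two steps cannot be told apart: the same change on two cores in this assay, a 2.8-fold higher number (0.45 log units; beyond the scatter) from compound 2 to compound 1 and a 1.5-fold higher number (0.17 log units; within the scatter) from compound 3 to compound 4, 1.9-fold (0.28 log units) apart, within the scatter of two such steps The change can therefore be carried from one of these cores to the other without a detectable difference in the size of its step, but this does not show that it raises the number on every core, since only the earlier step lies beyond the scatter, and two steps cannot separate the influence of the core from that of the place, with the nitro of compound 4 sitting ortho to a fused ring and meta to a fused ring and that of compound 1 sitting elsewhere.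

The compounds shown carry only methyl or nitro on the six-membered ring, so it remains open how a chlorine, a methoxy group, an amine or a carboxylic acid there would read in this assay. Also open, on these data alone, is whether a longer chain in place of methyl would behave alike on the two cores.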